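The source may hold more compounds than are shown below. What is called first, only, known or untested is meant among the compounds shown, and "the series" means these compounds.

Compound 3 `COc1cc(NC(C)CCCN2C(=O)CN(C(=O)CN)C2(C)C)c2ncccc2c1` is the most soluble of the three compounds measured in a physicochemical assay for solubility (on this read-out higher numbers stand for higher solubility and lower numbers for lower solubility), where compound 3 gives 150000 ug/mL. Compound 2 `COc1cc(NC(C)CCCN2C(=O)CN(C(=O)[C@H](N)CC(C)C)C2(C)C)c2ncccc2c1`, which carries an isobutyl group on the saturated chain carbon bound to an amine nitrogen and a carbonyl carbon, gives 26600 ug/mL in this assay, and compound 1 `COc1cc(NC(C)CCCN2C(=O)CN(C(=O)[C@H](N)CCSC)C2(C)C)c2ncccc2c1`, with a 2-(methylsulfanyl)ethyl group at that place, gives 11700 ug/mL. The step of a 2.3-fold higher number from compound 1 to compound 2 (0.36 log units; beyond the scatter) is modest, the step of a 5.6-fold higher number from compound 2 to compound 3 (0.75 log units; beyond the scatter) is modest as well, and the step of a 13-fold higher number from compound 1 to compound 3 (1.11 log units; beyond the scatter) is large.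

Compound 4 `COc1cc(NC(C)CCCN2C(=O)CN(C(=O)[C@H](N)C(C)C)C2(C)C)c2ncccc2c1` differs from compound 3 by isopropyl in place of hydrogen on a saturated chain carbon bound to an amine nitrogen and a carbonyl carbon. The step that bears most directly on this change is a 5.6-fold higher number from compound 2 to compound 3 (0.75 log units; beyond the scatter), read in reverse: a side chain entering on that carbon in place of hydrogen went with a lower number, and the step of a 13-fold higher number from compound 1 to compound 3 (1.11 log units; beyond the scatter) points the same way. Isopropyl is a close relative of isobutyl, so a downward step beyond the scatter is expected for compound 4, though somewhat smaller than that seen with isobutyl, and the step is expected to be a 3.0-fold lower number from compound 3 to compound 4 (0.48 log units; beyond the scatter). Compound 4 is therefore estimated at 50000 ug/mL in this assay, with a range expected from 25000 ug/mL to 100000 ug/mL.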

Compound 4, solubility: 46500 ug/mL
Beside the measured number, compound 4's estimate is 1.1-fold (0.03 log units) above it; the measured number falls inside the stated range.
By their numbers in this assay, from the lowest: compound 1; then compounds 2 and 4 (each within the scatter of the next); then compound 3.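

With isopropyl on the saturated chain carbon bound to an amine nitrogen and a carbonyl carbon, this assay gives a 3.2-fold lower number from compound 3 to compound 4 (0.51 log units; beyond the scatter) as a third case, so isopropyl, isobutyl and 2-(methylsulfanyl)ethyl at this place all stand lower than hydrogen, and no compound shown goes against this. Within the data shown here, the new result also shows that the two branched hydrocarbon side chains are not told apart here, since a 1.7-fold higher number from compound 2 to compound 4 (0.24 log units; within the scatter) leaves compounds 2 and 4 level within the usual scatter, while the earlier compounds offered no such comparison. The sulfur-bearing side chain, by contrast, stands apart from isopropyl, with a 4.0-fold higher number from compound 1 to compound 4 (0.60 log units; beyond the scatter) as the measure of that gap, and this leaves compound 1 the lowest of the four.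

The compounds shown leave open whether a single methyl on this carbon would already bring the lower number, and whether a side chain ending in an amine, a carboxylic acid or a hydroxyl group would stand nearer compound 3 than compounds 2 and 4. Nothing given here explains why these side chains differ.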